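The compounds below may be only part of what the source reports. "The series", "measured", "known", "first", "only" and "open" are said of these compounds alone.

Compound 1 `O=C1NC(=S)S/C1=C\c1cc2cc(Cl)ccc2nc1Cl` in a toxicity assay on THP-1 cells (Homo sapiens) for cytotoxicity, read by MTT assay, with a stated time of 48 h (a higher number here means a weaker inhibitor of growth, a lower number a stronger inhibitor of growth), gives > 100 ug/mL, which is a limit of the measurement and not a number.
Compound 2 `Cc1cccc2cc(/C=C3\SC(=S)N(CC(=O)O)C3=O)c(Cl)nc12` in this assay gives > 100 ug/mL, again a limit and not a number.

Compound 2 thus stands at the edge of what this assay can report, and compound 1 stands at the same edge; the two cannot be ranked against each other. Going by the values given here, the one piece of evidence is the limit of > 100 ug/mL in this assay, at which 2 of the 2 values shown sit. Compound 3 `Cc1cccc2cc(/C=C3\SC(=S)NC3=O)c(Cl)nc12` has not yet been measured. It differs from compound 2 in one place: hydrogen in place of carboxymethyl on an amide-type nitrogen in a ring. Among the compounds with values here, no measured pair carries this change, so no step size can be read from the data. Given (the limit of > 100 ug/mL in this assay, at which 2 of the 2 values shown sit), the expected step that the limit leaves unreadable from compound 2 to compound 3 is none beyond the usual scatter, and compound 3 is expected most likely to return a limit too. Compound 3 is estimated at 150 ug/mL, with a range from 50 ug/mL to 500 ug/mL.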

Compound 3, concentration for 50% growth inhibition: > 100 ug/mL
Compound 3: only a limit was reported (the forecaster's own chance of this, stated with the estimate: 80%); the middle value does not contradict the limit.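

Compound 2 and compound 3 both return a limit and not a number in this assay, so no step can be read between them. The compounds shown leave open how strongly any of them inhibits growth, and whether exchanging carboxymethyl for hydrogen changes it.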